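A few compounds are considered here, and "the series" means these few. Any claim that something is new, unique, unknown or untested is made for them only; others in the source may bear on it.

Measured so far:
compound 1, `Cn1ccc2cc(-c3cc4nccc(-c5ccc(F)cc5)n4n3)ccc21` — 4780 nM
compound 2, `COc1ccc(-c2cc3nccc(-c4cc(OC)c(OC)c(OC)c4)n3n2)cc1[N+](=O)[O-]` — > 10000 nM
compound 3, `COc1ccc(-c2cc3nccc(-c4cc(OC)c(OC)c(OC)c4)n3n2)cc1F` — 3950 nM

In a functional assay on B16-F0 cells (Mus musculus) for inhibition, read by CCK-8 assay, with a stated time of 48 h (on this read-out lower numbers stand for stronger inhibition and higher numbers for weaker inhibition), compound 3 gives 3950 nM, and compound 1 gives a number within the scatter of that, 4780 nM. Compound 2 gives only a limit of the assay, > 10000 nM, which is the limit of > 10000 nM in this assay, at which 1 of the 3 values shown sits. For the measured compounds named here, the one step measured in one place is an at least 2.5-fold lower number from compound 2 to compound 3 (0.40 log units; beyond the scatter), a change on the same aryl ring that compound 4 alters.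

Compound 4, `COc1cc(-c2ccnc3cc(-c4cccc(C)c4)nn23)cc(OC)c1OC`, differs from compound 3 by 3-methylphenyl in place of 3-fluoro-4-methoxyphenyl on an aromatic carbon. Going by the values given here, no measured step swaps out the whole of this ring, and the step from compound 2 to compound 3 tells only that a nitro group there is unfavourable. Since compound 3 and compound 1 sit close together with differently substituted aryl groups, the step into compound 4 in this assay is expected to stay within the scatter, in no clear direction, as a 1.3-fold higher number from compound 3 to compound 4 (0.10 log units; within the scatter). Compound 4 is therefore estimated at 5000 nM, between 1500 nM and 16000 nM.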

Compound 4, half-maximal inhibitory concentration: 2220 nM
The estimate for compound 4 lay 2.3-fold (0.35 log units) above the measured number, and the stated range covers the measured number.
By their numbers in this assay, from the lowest: compounds 4, 3 and 1 (each within the scatter of the next, the first and the last beyond it). At a limit, above all of these: compound 2.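

In this assay, putting 3-methylphenyl in place of 3-fluoro-4-methoxyphenyl on this aromatic carbon, next to the ring nitrogen, gives a 1.8-fold lower number from compound 3 to compound 4 (0.25 log units; within the scatter). Where the earlier step changed only one substituent on the ring, this one exchanges the whole aryl group, and the number stays within the scatter. The methoxy and fluoro groups of compound 3 are thus not needed to hold this level, since compound 4 carries neither and has a methyl group instead, though nothing measured here explains the step.

On these data alone, whether a plain phenyl ring would do the same remains open. So does the outcome with an amine or a carboxylic acid on this ring, or with a saturated ring such as cyclohexyl in place of the aryl group.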